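The source may report more compounds than this note shows. Statements on the series, on what has been measured and on what is new or still open speak of the compounds shown alone.

Compound 1 `CC[C@@H]1C(=O)N(C)c2cnc(-n3ccc4cc(F)ccc43)nc2N1C1CCCC1`: "not active" (no number reported)
Compound 2 `CC[C@@H]1C(=O)N(C)c2cnc(-n3ccc4cc(C(=O)NC5CCCC5)ccc43)nc2N1C1CCCC1`: 795 nM
Compound 3 `CCNC(=O)c1ccc2c(ccn2-c2ncc3c(n2)N(C2CCCC2)[C@H](CC)C(=O)N3C)c1`: 784 nM

Of the compounds shown here, three built on one shared core have been tested in a functional assay on MCF7 cells (Homo sapiens) for antiproliferative activity, read by CCK-8 assay, with a stated time of 72 h; on this read-out higher numbers stand for weaker inhibition of growth and lower numbers for stronger inhibition of growth. Compound 1 is reported as "not active" (no number reported) with no number given. Compound 2 gives 795 nM and compound 3 gives 784 nM. Compound 3 thus holds the lower of the two numbers, but the gap to compound 2 lies within the scatter, so the two cannot be ranked. Within the data shown here, the single measured step, a 1.0-fold lower number from compound 2 to compound 3 (0.01 log units; within the scatter), exchanges ethyl for cyclopentyl on the amide nitrogen and changes nothing beyond the scatter.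

Compound 4 `CC[C@@H]1C(=O)N(C)c2cnc(-n3ccc4ccccc43)nc2N1C1CCCC1` has not yet been measured. Relative to compound 3 it differs in one place: hydrogen in place of ethylcarbamoyl on an aromatic carbon. Among the measured compounds shown here, no measured step removes the ethylcarbamoyl outright; the step from compound 2 to compound 3 only reshapes the amide and bears little on this change. Compound 1, which carries fluorine in place of an amide, is reported as not active, so loss of the amide has so far gone with loss of growth inhibition. Compound 4 is therefore expected to give a weaker result, with the step of a 7.7-fold higher number from compound 3 to compound 4 (0.88 log units; beyond the scatter) estimated toward a higher number. Compound 4 is estimated at 6000 nM, within a range of 1500 nM to 30000 nM, and with a real chance that only a limit is reported.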

Compound 4, concentration for 50% growth inhibition: 17200 nM
Estimate against measurement, compound 4: 2.9-fold (0.46 log units) below, within the range that was stated.
By their numbers in this assay, from the lowest: compounds 3 and 2 (each within the scatter of the next); then compound 4.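

In this assay, taking the ethylcarbamoyl off this aromatic carbon gives a 22-fold higher number from compound 3 to compound 4 (1.34 log units; beyond the scatter), and taking the cyclopentylcarbamoyl off the same carbon gives a 22-fold higher number from compound 2 to compound 4 (1.34 log units; beyond the scatter), so the loss of the amide now has a measured size, large and beyond the scatter. The two amides could not be ranked against each other, yet both stand well clear of hydrogen, so among the compounds shown, growth inhibition at this level goes with an amide on this carbon, whether its nitrogen bears ethyl or cyclopentyl. Nothing measured here accounts for the size of this step.

Compound 1 carries no number, so fluorine and hydrogen on this carbon cannot be compared by size. On these data alone, it also stays open whether a carboxylic acid, an amine, an unsubstituted carboxamide or an amide with a longer chain on its nitrogen would hold growth inhibition at the level of the two amides or fall back toward hydrogen.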